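The source may hold more compounds than are shown below. What is called first, only, known or untested is meant among the compounds shown, and "the series" means these compounds.

Measured so far:
Compound 1 `C/C(=N\NC(N)=S)c1ccc2[nH]c(-c3ccccc3)nc2c1`: >= 100000 nM
Compound 2 `C/C(=N\NC(N)=O)c1ccc2c(c1)nc(-c1ccccc1)n2C1CCCCC1`: "not determined" (no result reported)

Both entries come from an ADME assay on MT4 cells (Homo sapiens) for cytotoxicity, read by MTT assay, with a stated time of 96 h; on this read-out higher numbers stand for lower toxicity in this test and lower numbers for higher toxicity in this test. Compound 1 gives >= 100000 nM, which is a limit of the assay and not a number. On these data alone, compound 2 has no number at all, since its entry reads "not determined" (no result reported), so its standing in this assay is unknown.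

Compound 3 `C/C(=N\NC(N)=S)c1ccc2c(c1)nc(-c1ccccc1)n2C1CCCCC1` has not yet been measured. The change to follow is a group of 3 heavy atoms (1 carbon, 1 nitrogen, 1 sulfur; no ring) in place of a group of 3 heavy atoms (1 carbon, 1 nitrogen, 1 oxygen; no ring), on an amine nitrogen: carbamoyl leaves and a group of the same size enters, with sulfur in place of oxygen, on an amine nitrogen.

For the measured compounds named here, no measured step shows how much such a swap matters here. A moderate step toward lower numbers in this assay, meaning higher toxicity, is expected, though this is a judgement and not a result. Compound 3 is estimated at 30000 nM, with an expected range of 8000 nM to 100000 nM.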

Compound 3, half-maximal cytotoxic concentration: 20000 nM
The estimate for compound 3 lay 1.5-fold (0.18 log units) above the measured number; low and high end bracket the measured number.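

In this assay, cyclohexyl in place of hydrogen on an aromatic nitrogen gives an at least 5.0-fold lower number from compound 1 to compound 3 (0.69 log units; beyond the scatter), and this step lies beyond the scatter. For the compounds shown here, this is the first sign that this nitrogen matters for the read-out: with cyclohexyl there, compound 3 reaches a measurable number, and a lower number here means higher toxicity in this test. The entry for compound 1 is a limit and not a number, so the step gives only a minimum size: the limit of >= 100000 nM in this assay, at which 1 of the 3 values shown sits.

On these data alone, compound 2 has no result, so the step from carbamoyl to its sulfur counterpart cannot be read, and how much that swap matters stays unknown. Also open, as far as these compounds go, is whether cyclohexyl itself is needed, or whether a methyl group or a chain ending in an amine on the same nitrogen would give a similar number.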